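The source may report more compounds than this note shows. Statements on the series, on what has been measured and on what is new or still open speak of the compounds shown alone.

Two compounds carry the same core and are known in an assay on isolated protein for inhibition of Dihydrofolate reductase (Homo sapiens), read by spectrophotometry, with a stated time of 5 min; on this read-out lower numbers stand for stronger inhibition and higher numbers for weaker inhibition. Compound 1 `CCOC(=O)C1=C(C)N=C(SCC(=O)c2ccc(Cl)c([N+](=O)[O-])c2)NC1c1ccccc1` in this assay gives 3000 nM, whereas compound 2 `CCOC(=O)CSC1=NC(c2ccccc2)C(C(=O)OCC)=C(C)N1` in this assay gives 830 nM. Of these two numbers, compound 2 has the lower one, and the gap between compound 2 and compound 1 lies beyond the scatter, so compound 2 stands as the stronger inhibitor of the pair. Compound 3 `CCOC(=O)CSC1=NC(c2ccccc2OC)C(C(=O)OCC)=C(C)N1` has not been measured in this assay; it differs from compound 2 in one place only: methoxy in place of hydrogen on an aromatic carbon, in words a methoxy in place of hydrogen on an aromatic carbon. Going by the values given here, no measured pair shows what such a change does on this core, so no step of known size guides the expectation, and the estimate for compound 3 rests on the number of compound 2 alone. With a change of two heavy atoms on the ring, a step no larger than the scatter is expected in either direction, and compound 3 is therefore expected to give about 900 nM, within a range from 300 nM to 3000 nM, which means an expected step of a 1.1-fold higher number from compound 2 to compound 3 (0.04 log units; within the scatter).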

Compound 3, half-maximal inhibitory concentration: 7300 nM
Compound 3: the middle estimate sits 8.1-fold (0.91 log units) below what was measured; the measured number lies above the stated range.
By their numbers in this assay, from the lowest: compound 2; then compound 1; then compound 3.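

In this assay, replacing phenyl with 2-methoxyphenyl produces an 8.8-fold higher number from compound 2 to compound 3 (0.94 log units; beyond the scatter), so this addition of 2 heavy atoms weakens inhibition by a clear margin. Going by these compounds alone, this is the first comparison on the shared core in which only one place changes, and it shows that the aromatic carbon ortho to a large group is not indifferent to what it carries: here, hydrogen gives the stronger inhibitor and methoxy the weaker one. The measurements show the size and direction of this step, but no supporting data explain why inhibition weakens.

The compounds shown leave open whether any group at this place would weaken inhibition or whether the loss is particular to methoxy, a question that a fluorine atom, a methyl, a hydroxyl or an amine at the same carbon could help answer. They also leave open whether methoxy would cost as much at another carbon of the same ring, or on the version of the core that carries the side chain of compound 1.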